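This account rests on a few compounds, and the source may have more. Where it says the series, first, only, none or still open, it means among the compounds named here.

Compound 1 `CCCc1nc(-c2ccccc2)c(CNCCN2CCN(c3ccc(Cl)cc3)CC2)o1` and compound 2 `CCCc1nc(-c2ccccc2)c(CNCCN2CCN(c3ccc(C)cc3)CC2)o1` share one core and differ only in the group carried on the amine nitrogen in a ring. In an assay on HEK293 cells for inhibition of Voltage-dependent T-type calcium channel subunit alpha-1G (Homo sapiens), read by fluorescence, tested at 10 uM (on this read-out lower numbers stand for less inhibition and higher numbers for more inhibition at the one concentration tested (going by the name of the read-out)), compound 1 gives 55.8%, and in the same test compound 2 gives 48.1%. The step of a number 7.7 percentage points lower from compound 1 to compound 2 (within the scatter) lies within the scatter, so the two compounds cannot be told apart; compound 2 stands lowest of the two numbers shown, with compound 1 the nearest and inside the scatter of it. Compound 3 `CCCc1nc(-c2ccccc2)c(CNCCN2CCN(c3cccc(OC)c3)CC2)o1` has not yet been measured. It differs from compound 2 by 3-methoxyphenyl in place of 4-methylphenyl on an amine nitrogen in a ring: the 4-methylphenyl leaves and a 3-methoxyphenyl enters, bringing one hydrogen-bond acceptor. Within the data shown here, no measured step covers a methoxy group, and the one step at this place, from chloro to methyl, stayed within the scatter. On that basis the step of a number 0.1 percentage points lower from compound 2 to compound 3 (within the scatter) is expected to be none beyond the scatter. Compound 3 is therefore estimated at 48% in this assay, within a range from 30% to 65%.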

Compound 3, a percentage reported as inhibition, at one concentration (the size of the read-out at that concentration, not a potency): 40.2%
Beside the measured number, compound 3's estimate is 7.8 percentage points above it, and the stated range covers the measured number.
By their numbers in this assay, from the lowest: compounds 3, 2 and 1 (each within the scatter of the next, the first and the last beyond it).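

Among these compounds, at the group carried on the amine nitrogen in a ring, the two steps that end at compound 3 read differently in this assay: the step of a number 7.9 percentage points lower from compound 2 to compound 3 (within the scatter) leaves those two compounds indistinguishable, while the step of a number 15.6 percentage points lower from compound 1 to compound 3 (beyond the scatter) is the first in this small set to clear the scatter, if only modestly. This position is therefore not wholly indifferent to what it carries, but the 3-methoxyphenyl separates only from the 4-chlorophenyl and not from the 4-methylphenyl, so the three compounds form no clean ranking. Nothing available here explains why compound 1 and compound 3 differ.

Compound 3 differs from compound 1 in both the kind of group on the aromatic ring and the place it occupies, so the two contributions cannot be pulled apart. A 3-chlorophenyl or a 4-methoxyphenyl would separate them, and a plain phenyl would show what the ring gives with no added group at all.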